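Propoxy to acetoxy on the shared core

The compounds below may be only part of what the source reports. "The series", "measured", "known", "first", "only" and "open" are said of these compounds alone.

In a functional assay on PC-3 cells (Homo sapiens) for cytotoxicity (a lower number here means a stronger inhibitor, a higher number a weaker inhibitor), compound 1 `CCOc1ccc(C(=O)/C=C/c2ccccc2)c(O)c1` gives 8080 nM. Compound 2 `CCCOc1ccc(C(=O)/C=C/c2ccccc2)c(O)c1` gives 8080 nM, level with compound 1 at the digits shown, its only measured neighbour. Among the measured compounds shown here, the single measured step, no change at the digits printed from compound 1 to compound 2 (within the scatter), is methyl in place of hydrogen on a saturated chain carbon, two bonds along the chain from an oxygen on an aromatic ring.

Compound 3 `CC(=O)Oc1ccc(C(=O)/C=C/c2ccccc2)c(O)c1` carries acetyl in place of propyl on an oxygen on an aromatic ring. Read one bond further out, this is propoxy to acetoxy. For the measured compounds named here, no measured step covers an acetyl, so the chain step bears only loosely, and it gives no ground for expecting a shift beyond the scatter in this assay. The expected step is a 1.1-fold higher number from compound 2 to compound 3 (0.05 log units; within the scatter). For compound 3 the estimated value is 9000 nM, with an expected range of 3500 nM to 25000 nM.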

Compound 3, half-maximal inhibitory concentration: 8080 nM
Compound 3: middle estimate off by 1.1-fold (0.05 log units), on the high side; low and high end bracket the measured number.
By their numbers in this assay, from the lowest: compounds 1, 2 and 3 (each within the scatter of the next).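

In this assay, acetyl on the oxygen on the aromatic ring reads the same as either saturated chain: acetyl in place of propyl gives no change at the digits printed from compound 2 to compound 3 (within the scatter), and acetyl in place of ethyl gives no change at the digits printed from compound 1 to compound 3 (within the scatter). The earlier step only lengthened a saturated chain, whereas this change brings in a group with a hydrogen-bond acceptor and a double bond outside aromatic rings, and the number still holds. No measurement on hand offers any account of this flat reading.

From the compounds shown here alone, whether any group on this oxygen can move the number beyond the scatter remains open, since all three compounds sit level. A longer chain such as hexyl, a chain ending in an amine or a carboxylic acid, or a benzoyl group in place of acetyl would test this.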